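The compounds below may be only part of what the source reports. "The series", "measured", "known", "first", "only" and "open" are said of these compounds alone.

In a functional assay on CCRF-CEM cells (Homo sapiens) for inhibition, with a stated time of 72 h (on this read-out lower numbers stand for stronger inhibition and higher numbers for weaker inhibition), compound 1 `[N-]=[N+]=NCc1ncnc2c1ncn2[C@@H]1O[C@H](CO)[C@@H](O)[C@H]1O` gives 390 nM, while compound 2 `OC[C@H]1O[C@@H](n2cnc3c(COc4ccccn4)ncnc32)[C@H](O)[C@@H]1O` gives 16600 nM, the higher of the two numbers shown. Going by the values given here, the one measured step, a 43-fold higher number from compound 1 to compound 2 (1.63 log units; beyond the scatter), is large and beyond the scatter, and it puts (pyridin-2-yl)oxy in place of azido on a saturated chain carbon bound to an aromatic carbon. Compound 3 `CSCc1ncnc2c1ncn2[C@@H]1O[C@H](CO)[C@@H](O)[C@H]1O` changes that same place, with methylsulfanyl in place of (pyridin-2-yl)oxy on a saturated chain carbon bound to an aromatic carbon. Among the compounds with values here, only that step bears on the change. Read backwards, it suggests that losing (pyridin-2-yl)oxy could bring a large drop in the number, although no measured compound carries methylsulfanyl, so azido is an imperfect guide. The expected change is an 11-fold lower number from compound 2 to compound 3 (1.04 log units; beyond the scatter), a large step towards a lower number in this assay. For compound 3 the estimated value is 1500 nM, with an expected range of 200 nM to 9000 nM.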

Compound 3, half-maximal inhibitory concentration: 15000 nM
For compound 3 the middle estimate is 10-fold (1.00 log units) below the measured one; measured number outside the range, above it.
By their numbers in this assay, from the lowest: compound 1; then compounds 3 and 2 (each within the scatter of the next).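

In this assay, the exchange of the ring-bearing (pyridin-2-yl)oxy for methylsulfanyl, which has no ring, gives a 1.1-fold lower number from compound 2 to compound 3 (0.04 log units; within the scatter), so this position does not separate these two groups. Set against that, a 38-fold higher number from compound 1 to compound 3 (1.59 log units; beyond the scatter) is of the same large kind as a 43-fold higher number from compound 1 to compound 2 (1.63 log units; beyond the scatter), so azido now stands apart from two different groups at this place, not just one, and among these three compounds only compound 1 has the low number. No evidence is available to explain why azido stands apart here. Going by these compounds, whether an amine or a hydroxyl on this carbon would fall with azido or with the other two groups remains open. So does the question of whether a longer chain on the sulfur of methylsulfanyl would change the number at all.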